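Swapping the nitrophenyl arm for an isopropyl group

This account rests on a few compounds, and the source may have more. Where it says the series, first, only, none or still open, it means among the compounds named here.

Measured so far:
compound 1 `CCCCCc1nnc(-c2ccc(O[C@@H]3O[C@H](COC(C)=O)[C@@H](OC(C)=O)[C@H](OC(C)=O)[C@H]3OC(C)=O)cc2)o1` — 21.5%
compound 2 `CC(=O)OC[C@H]1O[C@@H](Oc2ccc(-c3nnc(-c4ccc([N+](=O)[O-])cc4)o3)cc2)[C@H](OC(C)=O)[C@@H](OC(C)=O)[C@@H]1OC(C)=O` — 58%

Both compounds were tested in a functional assay on MDA-MB-231 cells (Homo sapiens) for inhibition, read by MTT assay, with a stated time of 24 h, tested at 100 uM; a lower number here means less inhibition, a higher number more inhibition at the concentration tested (going by the name of the read-out). Compound 1 gives 21.5%, whereas compound 2 gives 58%, which makes compound 2 the higher of the two numbers shown, and the only step known so far is a number 36.5 percentage points higher from compound 1 to compound 2 (beyond the scatter).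

Compound 3 `CC(=O)OC[C@H]1O[C@@H](Oc2ccc(-c3nnc(C(C)C)o3)cc2)[C@H](OC(C)=O)[C@@H](OC(C)=O)[C@@H]1OC(C)=O` has not yet been tested. It keeps the shared core and the sugar portion of compound 2 but differs at one place: isopropyl in place of 4-nitrophenyl on an aromatic carbon. Within the data shown here, the only measured step that bears on this change is the one from compound 1 to compound 2, where a pentyl chain was exchanged for a 4-nitrophenyl group and the inhibition rose strongly, a number 36.5 percentage points higher from compound 1 to compound 2 (beyond the scatter). The move to compound 3 goes the other way, back from 4-nitrophenyl to a short alkyl group, so a step of roughly that size in the downward direction is expected, a number 33 percentage points lower from compound 2 to compound 3 (beyond the scatter). For compound 3 the expected inhibition in this assay is therefore about 25%, with a range from 10% to 45%.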

Compound 3, a percentage reported as inhibition, at one concentration (the size of the read-out at that concentration, not a potency): 11.9%
Compound 3: the middle estimate sits 13.1 percentage points above what was measured, and the stated range covers the measured number.
By their numbers in this assay, from the lowest: compounds 3 and 1 (each within the scatter of the next); then compound 2.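

In this assay, this aromatic carbon of the five-membered ring now has one aryl group and two alkyl groups compared, and replacing the 4-nitrophenyl group with isopropyl gives a number 46.1 percentage points lower from compound 2 to compound 3 (beyond the scatter). The earlier step could have been specific to pentyl, but this one shows that the high number of compound 2 also stands apart from a second, shorter and branched alkyl group, while isopropyl in place of pentyl gives a number 9.6 percentage points lower from compound 1 to compound 3 (within the scatter), so this pair shows no measurable difference between the two alkyl groups. Nothing measured here explains the gap between compound 2 and the two alkyl compounds.

Going by these compounds, what remains open is whether the aromatic ring alone is enough to keep the higher number or whether the nitro group on it is needed, which a plain phenyl group or a phenyl ring carrying an amine or a methoxy group in place of the nitro group would help to separate. On these data alone, it is also open whether a hydroxyl group or a carboxylic acid at the end of an alkyl chain would lift the low numbers of the alkyl compounds.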